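Dropping the bromine from the aryl piperazine sulfonamide

The source may hold more compounds than are shown below. What is called first, only, known or untested is meant among the compounds shown, and "the series" means these compounds.

Of the compounds shown here, three sharing one core have been measured in an assay on CHO cells for displacement of a labelled ligand from adenosine receptor A2b (Homo sapiens), read by scintillation counting, with a stated time of 75 min, in the presence of a further agent that is not named here; a lower number here means a stronger inhibitor, a higher number a weaker inhibitor. Compound 1 `CCCn1c(=O)[nH]c2nc(-c3ccc(S(=O)(=O)N4CCN(Cc5ccc(Br)cc5)CC4)cc3)[nH]c2c1=O` gives 0.153 nM. Compound 2 `CCCn1c(=O)[nH]c2nc(-c3ccc(S(=O)(=O)N4CCN(c5cccc(F)c5)CC4)cc3)[nH]c2c1=O` gives 0.632 nM. Within the data shown here, compound 3 `CCCn1c(=O)[nH]c2nc(-c3ccc(S(=O)(=O)N4CCN(c5ccc(Br)cc5)CC4)cc3)[nH]c2c1=O` gives 0.0835 nM, the lowest of the three numbers, though its gap to compound 1 is within the scatter; only the step of a 7.6-fold lower number from compound 2 to compound 3 (0.88 log units; beyond the scatter) lies beyond it.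

Compound 4 `CCCn1c(=O)[nH]c2nc(-c3ccc(S(=O)(=O)N4CCN(c5ccccc5)CC4)cc3)[nH]c2c1=O` has not been measured. The change from compound 3 is hydrogen in place of bromo on an aromatic carbon, that is, 4-bromophenyl becomes phenyl on the amine nitrogen in the ring. Among the measured compounds shown here, no measured pair removes a substituent outright, so no step speaks to it directly. The nearest guide is a 7.6-fold lower number from compound 2 to compound 3 (0.88 log units; beyond the scatter), where a different halogen in a different position sat on the same ring, and a 1.8-fold lower number from compound 1 to compound 3 (0.26 log units; within the scatter), which was within the scatter. On that thin basis a modest rise in the number is expected, and compound 4 is estimated at 0.2 nM, in a range from 0.06 nM to 0.7 nM, corresponding to the expected step of a 2.4-fold higher number from compound 3 to compound 4 (0.38 log units; beyond the scatter).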

Compound 4, inhibition constant: 0.643 nM
The estimate for compound 4 lay 3.2-fold (0.51 log units) below the measured number, within the range that was stated.
By their numbers in this assay, from the lowest: compounds 3 and 1 (each within the scatter of the next); then compounds 2 and 4 (each within the scatter of the next).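

In this assay, taking the bromine off the 4-bromophenyl group gives a 7.7-fold higher number from compound 3 to compound 4 (0.89 log units; beyond the scatter) and so shows, in a direct pair, that this substituent on the aromatic ring counts for binding. Fluoro does not show the same effect, although it sits at a different place on the ring, since hydrogen in place of fluoro gives a 1.0-fold higher number from compound 2 to compound 4 (0.01 log units; within the scatter) and leaves the 3-fluorophenyl and phenyl compounds within the scatter of each other. The bromine also separates two comparisons with the 4-bromobenzyl compound, as 4-bromophenyl stayed within the scatter of it while phenyl gives a 4.2-fold higher number from compound 1 to compound 4 (0.62 log units; beyond the scatter) and lies beyond the scatter.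

On these data alone, whether chloro, methyl or methoxy on that same aromatic carbon would match bromo remains open. No measurement shown here explains why removing the bromine has this effect.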